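Lactone to sulfonamide chain on the shared core

This account rests on a few compounds, and the source may have more. Where it says the series, first, only, none or still open, it means among the compounds named here.

Measured so far:
compound 1, `CCOc1ccccc1-c1ccc(-c2nc3cnccc3c(N[C@@H]3CCOC3=O)c2C#N)cc1`: 2.7
compound 2, `CC[C@@H](Nc1c(C#N)c(-c2ccc(-c3ccc(F)cc3)cc2)nc2cnccc12)C(N)=O`: 2.7

In a physicochemical assay for lipophilicity, read by HPLC, at pH 7.5 (on this read-out lower numbers stand for lower lipophilicity and higher numbers for higher lipophilicity), compound 1 gives 2.7, and compound 2 gives 2.7; the two stand level at the digits shown, and the gap between them lies within the usual scatter of the measurement. For the measured compounds named here, no pair among the measured compounds differs in only one place, so no measured step is available as a guide.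

Compound 3, `CCOc1ccccc1-c1ccc(-c2nc3cnccc3c(NC(CC)CNS(=O)(=O)C3CC3)c2C#N)cc1`, has not yet been measured in this assay. Against compound 1 it shows the following change: a group of 11 heavy atoms (7 carbon, 1 nitrogen, 2 oxygen, 1 sulfur; one three-membered non-aromatic ring of carbon only) in place of a group of 6 heavy atoms (4 carbon, 2 oxygen; one five-membered non-aromatic ring with 1 hetero atom), on a nitrogen on an aromatic ring.

Going by the values given here, with no measured step to lean on, the expectation rests on the size of the change alone. A small step upward in this assay is expected, of a number 0.30 log units higher from compound 1 to compound 3 (within the scatter), but one that may still sit within the scatter. Compound 3 is therefore estimated at 3, with a range from 2.4 to 3.6.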

Compound 3, distribution coefficient: 3.6
The estimate for compound 3 lay 0.60 log units below the measured number; measured number inside the range.
By their numbers in this assay, from the lowest: compounds 1 and 2 (each within the scatter of the next); then compound 3.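

For the compounds shown here, this is the first step measured at this position, on a nitrogen on an aromatic ring, since compound 1 and compound 2 differ in more than one place. In this assay, the position proves sensitive to what it carries: 2-oxooxolan-3-yl gives way to the sulfonamide chain of 11 heavy atoms, with a number 0.90 log units higher from compound 1 to compound 3 (beyond the scatter). The exchange changes several things at once, including the size of the group, the ring it holds, its hydrogen-bond donor count and its defined stereocentre, and nothing measured ties the step to any one of them.

The compounds shown leave open how much of the step belongs to the three-membered ring and how much to the sulfonamide itself. An amine or a carboxylic acid at the end of the same chain, or a shorter chain, would test this.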